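The source may hold more compounds than are shown below. What is called first, only, known or untested is meant among the compounds shown, and "the series" means these compounds.

Measured compounds:
compound 1, `CC(C)(C)OC(=O)NCCNC(=O)CN1CN(c2ccccc2)C2(CCN(C(=O)c3ccc(C(C)(C)C)cc3)CC2)C1=O`: 10900 nM
compound 2, `O=C(CN1CN(c2ccccc2)C2(CCN(C(=O)c3ccc(C4CCCCC4)cc3)CC2)C1=O)N1CCC(CO)CC1`: 1100 nM
compound 3, `COC(=O)CCCNC(=O)CN1CN(c2ccccc2)C2(CCN(C(=O)c3ccc(C4CCCCC4)cc3)CC2)C1=O`: 2500 nM

In an assay on HEK293 cells for displacement of a labelled ligand from NPC1-like intracellular cholesterol transporter 1 (Homo sapiens) (on this read-out lower numbers stand for stronger inhibition and higher numbers for weaker inhibition), compound 1 gives the highest number of the three, so it displaces the labelled ligand least readily. Compound 3 gives 2500 nM and compound 2 gives 1100 nM; both sit well below compound 1, and both carry a cyclohexyl group on the aromatic ring where compound 1 carries a tert-butyl group, so neither is a single-change partner of compound 1.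

Compound 4, `CC(C)(C)c1ccc(C(=O)N2CCC3(CC2)C(=O)N(CC(=O)NCNS(C)(=O)=O)CN3c2ccccc2)cc1`, keeps the tert-butyl side of compound 1 and alters only the chain hanging from the amide nitrogen: methanesulfonamido in place of ((tert-butoxycarbonyl)amino)methyl on a saturated chain carbon bound to an amide-type nitrogen

Going by the values given here, no measured step touches this exact change. Among the compounds with values here, the only single-change step in the set, a 2.3-fold higher number from compound 2 to compound 3 (0.36 log units; beyond the scatter), concerns the same chain region and shows that swapping one polar end group for another there moves this assay by a modest amount. On that footing, the step of a 1.4-fold lower number from compound 1 to compound 4 (0.13 log units; within the scatter) is expected to be small, most likely a slight drop in the number, but with wide uncertainty. Compound 4 is therefore estimated at 8000 nM, with a range from 2500 nM to 25000 nM.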

Compound 4, half-maximal inhibitory concentration: 3200 nM
Compound 4: the middle estimate sits 2.5-fold (0.40 log units) above what was measured; the range from low to high includes it.
By their numbers in this assay, from the lowest: compound 2; then compounds 3 and 4 (each within the scatter of the next); then compound 1.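

In this assay, the earlier step showed only that the end of this chain matters on the cyclohexyl compounds. Replacing ((tert-butoxycarbonyl)amino)methyl with methanesulfonamido on a saturated chain carbon bound to an amide-type nitrogen now gives a 3.4-fold lower number from compound 1 to compound 4 (0.53 log units; beyond the scatter), so the chain end also matters on the tert-butyl side. The entering group has 5 heavy atoms against 9 for the group that leaves, while both have 1 hydrogen-bond donor and 2 hydrogen-bond acceptors, and no measurement shown here explains why the number falls.

This single step cannot separate the loss of the tert-butoxycarbonyl part from the arrival of the sulfonyl group, and a free primary amine, an acetamide or a carboxylic acid at the same chain end would help to tell the two apart. The compounds shown also leave open whether the same swap would move the number in the same direction with cyclohexyl in place of tert-butyl on the aromatic ring.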